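Changing the amide substituent on a shared nucleoside core

This account rests on a few compounds, and the source may have more. Where it says the series, first, only, none or still open, it means among the compounds named here.

Compound 1 `NC(=O)[C@H]1OC(n2cnc3c(N)ncnc32)[C@H](O)[C@@H]1O`: 64 nM
Compound 2 `CCCCCCCCNC(=O)[C@H]1OC(n2cnc3c(N)ncnc32)[C@H](O)[C@@H]1O`: 21 nM
Compound 3 `CC(C)CONC(=O)[C@H]1OC(n2cnc3c(N)ncnc32)[C@H](O)[C@@H]1O`: 20 nM

In an assay on cell membranes for binding affinity to 2-oxoglutarate receptor 1 (Rattus norvegicus), read by radioligand binding (on this read-out higher numbers stand for weaker inhibition and lower numbers for stronger inhibition), compound 2 stands second highest of the three numbers. It is separated from compound 1 by a 3.0-fold lower number from compound 1 to compound 2 (0.48 log units; beyond the scatter), while a 1.1-fold lower number from compound 2 to compound 3 (0.02 log units; within the scatter) lies within the scatter. Compound 4 `COc1ccc(CNC(=O)[C@H]2OC(n3cnc4c(N)ncnc43)[C@H](O)[C@@H]2O)cc1OC` differs from compound 2 by 3,4-dimethoxyphenyl in place of heptyl on a saturated chain carbon bound to an amide-type nitrogen. Both measured steps concern the group on the amide-type nitrogen: adding a substituent there lowered the number modestly, and exchanging octyl for isobutoxy changed nothing beyond the scatter. Among the measured compounds shown here, no measured step replaces a chain with an aromatic ring. Compound 4 is therefore expected to give about 22 nM, between 8 nM and 65 nM. That estimate corresponds to an expected 1.0-fold higher number from compound 2 to compound 4 (0.02 log units; within the scatter).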

Compound 4, inhibition constant: 140 nM
Compound 4: middle estimate off by 6.4-fold (0.80 log units), on the low side; measured number outside the range, above it.
By their numbers in this assay, from the lowest: compounds 3 and 2 (each within the scatter of the next); then compound 1; then compound 4.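

Compound 4 shows that a group on the amide-type nitrogen does not by itself lower the number in this assay: 3,4-dimethoxyphenyl in place of heptyl gives a 6.7-fold higher number from compound 2 to compound 4 (0.82 log units; beyond the scatter). Octyl and isobutoxy could not be told apart, so this is the first exchange between two substituted amides that goes beyond the scatter. Nothing available bears on the reason for this step.

As far as these compounds go, what remains open is whether the step goes with the aromatic ring or with its two methoxy groups, which a plain phenyl in the same place would separate. From the compounds shown here alone, how a butyl chain or a carboxylic acid there would read also remains open.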